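A few compounds are considered here, and "the series" means these few. Any claim that something is new, unique, unknown or untested is made for them only; others in the source may bear on it.

Working notes on the series. In a functional assay on Jurkat cells for inhibition of nuclear factor NF-kappa-B complex (Homo sapiens) (a higher number here means a weaker inhibitor, a lower number a stronger inhibitor), compound 1 `CCOC(=O)c1cnc(C)nc1NN1C(=O)C=C(C)C1=O` gives 16000 nM. Compound 2 `CCOC(=O)c1cnc(C(C)(C)C)nc1NN1C(=O)C=C(C)C1=O` gives 1000 nM in this assay, and compound 3 `CCOC(=O)c1cnc(-c2ccc(Cl)cc2)nc1NN1C(=O)C=C(C)C1=O` gives 300 nM. Compound 3 thus carries the lowest number of the three; the nearest step to it is a 3.3-fold lower number from compound 2 to compound 3 (0.52 log units; beyond the scatter), the furthest is a 53-fold lower number from compound 1 to compound 3 (1.73 log units; beyond the scatter), and the remaining step is a 16-fold lower number from compound 1 to compound 2 (1.20 log units; beyond the scatter). All three steps alter the group on the same aromatic carbon, and each replacement of methyl by a larger group brought a lower number.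

Compound 4 `CCOC(=O)c1cnc(C(=O)c2ccco2)nc1NN1C(=O)C=C(C)C1=O` differs from compound 3 by (furan-2-yl)carbonyl in place of 4-chlorophenyl on an aromatic carbon. Going by the values given here, no measured step exchanges an aromatic ring for a carbonyl-linked group at this position, so the earlier steps give only a loose guide: the entering group matches the leaving one in its count of heavy atoms, but the step of a 3.3-fold lower number from compound 2 to compound 3 (0.52 log units; beyond the scatter) shows that the kind of group matters beyond that count. The number for compound 4 is expected to move somewhat upward, a step of about a 2.7-fold higher number from compound 3 to compound 4 (0.43 log units; beyond the scatter). Compound 4 is therefore estimated at 800 nM, with a range from 200 nM to 4000 nM.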

Compound 4, half-maximal inhibitory concentration: 700 nM
The estimate for compound 4 lay 1.1-fold (0.06 log units) above the measured number, within the range that was stated.
By their numbers in this assay, from the lowest: compound 3; then compounds 4 and 2 (each within the scatter of the next); then compound 1.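

Going by these compounds alone, at the aromatic carbon between two ring nitrogen atoms, (furan-2-yl)carbonyl is the first group with hydrogen-bond acceptors and a double bond outside aromatic rings; in this assay it gives a 2.3-fold higher number from compound 3 to compound 4 (0.37 log units; beyond the scatter), so two groups with equal heavy-atom counts do not read alike. Exchanging tert-butyl for this group gives a 1.4-fold lower number from compound 2 to compound 4 (0.15 log units; within the scatter), and exchanging methyl for it gives a 23-fold lower number from compound 1 to compound 4 (1.36 log units; beyond the scatter), so the large gain over methyl is not confined to groups made only of carbon, or of carbon and chlorine. Nothing measured here accounts for these differences.

Open, from the compounds shown here alone, is whether the carbonyl link or the furan ring sets the number; a benzoyl group or a directly attached furan-2-yl would separate the two. Going by these compounds, how an amine or a carboxylic acid would read at this carbon also remains open.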